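A few compounds are considered here, and "the series" means these few. Any claim that something is new, unique, unknown or untested is made for them only; others in the source may bear on it.

In a functional assay on KB cells (Homo sapiens) for cytotoxicity, read by MTT assay, with a stated time of 72 h (a lower number here means a stronger inhibitor, a higher number a weaker inhibitor), compound 1 (`O=S(=O)(c1ccc(F)cc1)c1nc2ccccc2nc1N1CCCC1`) gives 30100 nM, compound 2 (`O=S(=O)(c1ccc(F)cc1)c1nc2ccccc2nc1N1CCc2ccccc2C1`) gives 35400 nM and compound 3 (`O=S(=O)(c1ccc(Br)cc1)c1nc2ccccc2nc1N1CCCC(O)C1`) gives 3720 nM, the lowest of the three numbers. Compound 4 (`O=S(=O)(c1ccc(F)cc1)c1nc2ccccc2nc1N1CCCC(O)C1`) differs from compound 3 in one place, with fluoro in place of bromo on an aromatic carbon. Among the measured compounds shown here, no measured step covers this exchange. The only one, a 1.2-fold higher number from compound 1 to compound 2 (0.07 log units; within the scatter), lies within the scatter and concerns a different place. Compound 1 carries 4-fluorophenyl and stands at 30100 nM, but it also differs from compound 3 elsewhere, so it gives only a loose hint of a rise. The expected change is a 2.2-fold higher number from compound 3 to compound 4 (0.33 log units; beyond the scatter). For compound 4 the estimated value is 8000 nM, with an expected range from 2500 nM to 25000 nM.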

Compound 4, half-maximal inhibitory concentration: 18300 nM
Beside the measured number, compound 4's estimate is 2.3-fold (0.36 log units) below it; the measured number falls inside the stated range.
By their numbers in this assay, from the lowest: compound 3; then compounds 4, 1 and 2 (each within the scatter of the next).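

In this assay, the exchange of 4-bromophenyl for 4-fluorophenyl is the only step shown at this position, and it lies beyond the scatter (a 4.9-fold higher number from compound 3 to compound 4 (0.69 log units; beyond the scatter)). With 4-fluorophenyl held constant, the exchanges of the other group for 3-hydroxypiperidin-1-yl stay within the scatter (a 1.9-fold lower number from compound 2 to compound 4 (0.29 log units; within the scatter); a 1.6-fold lower number from compound 1 to compound 4 (0.22 log units; within the scatter)). The bromo effect therefore rests on this single pair.

No evidence here bears on the reason for this step. From the compounds shown here alone, whether chloro, methoxy or an amine at this position would read closer to bromo or to fluoro remains open, as does whether bromo has the same effect alongside pyrrolidin-1-yl.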